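Cytotoxicity on a Shared Saturated Core: Chloride to Methyl Amide

The source may hold more compounds than are shown below. What is called first, only, known or untested is meant among the compounds shown, and "the series" means these compounds.

Measured compounds:
compound 1 `CC(=O)NC12CCCC3CC(CCC31)C2`, 3000000 nM
compound 2 `O=C(Cl)C12CCCC3CC(CCC31)C2`, no result reported

This account follows the step from compound 2 to compound 3. Two compounds of the shared core were put into an ADME assay (Gallus gallus) for cytotoxicity, read by microscopy, with a stated time of 24 h; a higher number here means that more compound is tolerated, a lower number that less compound is tolerated. Compound 1 gives 3000000 nM in this assay, so a very large amount of it is tolerated. Compound 2 returns no result reported in this assay, so it stands nowhere on the scale yet, and no direction can be set from it.

Compound 3 `CNC(=O)C12CCCC3CC(CCC31)C2` is the next compound to go into this assay. It differs from compound 2 in one place: methylamino in place of chloro on a carbonyl carbon. For the measured compounds named here, with no number for compound 2, no step can be sized from it; the only anchor is compound 1, which shares a carbonyl carbon bearing a nitrogen with compound 3, though no step between those two is given here.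

Compound 3 is therefore expected to land near where compound 1 stands, at about 3000000 nM, with a range from 1000000 nM to 10000000 nM.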

Compound 3, minimum cytotoxic concentration: 750000 nM
Compound 3: the middle estimate sits 4.0-fold (0.60 log units) above what was measured, and the stated range ends above it.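

In this assay, for the compounds shown here, putting methylcarbamoyl in place of acetamido on a saturated ring carbon gives a 4.0-fold lower number from compound 1 to compound 3 (0.60 log units; beyond the scatter), the first sign that the number at this position responds to which way round the amide is attached to the shared core, although compound 3, at 750000 nM, is still tolerated in large amounts. The step from chloro to methylamino on a carbonyl carbon cannot be read, as compound 2 has no number, so what is known about this position rests on this single pair of amides. No measurement is available that would account for the shift, and its origin remains unexplained.

The compounds shown leave open whether an amine or a carboxylic acid at this position would give a number nearer to that of compound 1 or nearer to that of compound 3, and whether a longer chain on the amide nitrogen would move it further. They also leave open whether the same exchange of acetamido for methylcarbamoyl would give a step of similar size and direction on any other core.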